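Swapping Butyl for 4-Hydroxyphenyl on a Quinolinone Imine

This account rests on a few compounds, and the source may have more. Where it says the series, first, only, none or still open, it means among the compounds named here.

Measured compounds:
Compound 1 `O=c1[nH]c2ccccc2cc1/C=N/c1ccc(O)cc1`: 92100 nM
Compound 2 `Cc1ccc2[nH]c(=O)c(/C=N/N)cc2c1`: 641000 nM
Compound 3 `CCCC/N=C/c1cc2cc(C)ccc2[nH]c1=O`: 63200 nM

In a functional assay, read by spectrophotometry, with a stated time of 30 min (on this read-out lower numbers stand for stronger inhibition and higher numbers for weaker inhibition), compound 3 gives the lowest number of the three, though compound 1 sits within the scatter of it, while compound 2 lies well above. Compound 4 `Cc1ccc2[nH]c(=O)c(/C=N/c3ccc(O)cc3)cc2c1` arises from compound 3 by 4-hydroxyphenyl in place of butyl on a double-bonded nitrogen. Within the data shown here, the only measured step at this position is a 10-fold lower number from compound 2 to compound 3 (1.01 log units; beyond the scatter), which does not involve 4-hydroxyphenyl. Compound 1, which carries 4-hydroxyphenyl on the same kind of nitrogen but lacks the methyl on the core, gives a number close to that of compound 3. A step of a 1.3-fold higher number from compound 3 to compound 4 (0.10 log units; within the scatter) is therefore expected, within the scatter. Compound 4 is estimated at 80000 nM, between 30000 nM and 220000 nM.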

Compound 4, half-maximal inhibitory concentration: 88500 nM
Beside the measured number, compound 4's estimate is 1.1-fold (0.04 log units) below it, and the stated range covers the measured number.
By their numbers in this assay, from the lowest: compounds 3, 4 and 1 (each within the scatter of the next); then compound 2.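

In this assay, 4-hydroxyphenyl in place of butyl on the double-bonded nitrogen gives a 1.4-fold higher number from compound 3 to compound 4 (0.15 log units; within the scatter) and so cannot be told apart from butyl, despite the added ring. Amino remains the group that stands apart, since replacing it with 4-hydroxyphenyl also gives a 7.2-fold lower number from compound 2 to compound 4 (0.86 log units; beyond the scatter) on the same nitrogen. The methyl on the core has no readable effect, with a 1.0-fold lower number from compound 1 to compound 4 (0.02 log units; within the scatter) as its step. Nothing measured here explains these results. On these data alone, whether a longer chain or a carboxylic acid on this nitrogen would move the number remains open.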